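The compounds below may be only part of what the source reports. "The series", "measured", "known", "first", "only" and "open" are said of these compounds alone.

Values in a functional assay on LS174T cells (Homo sapiens) for antiproliferative activity; on this read-out higher numbers stand for weaker inhibition and lower numbers for stronger inhibition:
- compound 1 `CN(C)c1ncc(/C=C/c2c(F)cccc2F)cn1`: > 200 nM
- compound 2 `CNc1ncc(/C=C/c2c(F)cccc2F)cn1`: > 200 nM
- compound 3 `CN(C)c1ncc(/C=C/c2c(F)cccc2Cl)cn1`: > 200 nM

Each of these entries is a limit and not a number.

Compound 3 stands at > 200 nM, which is a limit. The series offers only (the limit of > 200 nM in this assay, at which 3 of the 3 values shown sit), so compound 3 cannot be ranked against the others.

The next compound is compound 4 `CNc1ncc(/C=C/c2c(F)cccc2Cl)cn1`, with hydrogen in place of methyl on a nitrogen on an aromatic ring, dimethylamino to methylamino: hydrogen in place of methyl on a nitrogen on an aromatic ring.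

The same change on the fluoro analogue is a step that the two limits leave unreadable from compound 1 to compound 2. For the measured compounds named here, this is the closest precedent, and it gives no size. Going by the values given here, the only other measured step, chloro in place of fluoro, is a step that the two limits leave unreadable from compound 1 to compound 3, and it gives no size either.

No size or direction can therefore be carried over, and compound 4 is expected to remain at the limit, as compound 2 does at > 200 nM.

The expected change is a step that the limit leaves unreadable from compound 3 to compound 4.

For compound 4 the estimated value is 350 nM, with an expected range of 80 nM to 1500 nM.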

Compound 4, half-maximal inhibitory concentration: > 200 nM
Compound 4: a limit, no number; the forecaster's own chance of this, stated with the estimate: 70%; the middle value is on the limit's open side.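

Neither new step, compound 3 to compound 4 or compound 2 to compound 4, can be read, because all the entries are limits and not numbers: the limit of > 200 nM in this assay, at which 4 of the 4 values shown sit. The compounds shown leave open whether dimethylamino to methylamino or chloro in place of fluoro changes potency at all.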